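Swapping an Aryl Ether for a Saturated Ring

A few compounds are considered here, and "the series" means these few. Any claim that something is new, unique, unknown or untested is made for them only; others in the source may bear on it.

Compound 1, `CCCCC(Cc1cc(OCCc2ccccc2)cc(OCCc2ccccc2)c1)C(=O)O`: 4700 nM in an assay on isolated protein for inhibition of Polyunsaturated fatty acid 5-lipoxygenase (Homo sapiens), with a stated time of 10 min; on this read-out higher numbers stand for weaker inhibition and lower numbers for stronger inhibition.
Compound 2, `CCCC/C(=C\c1cc(OCc2ccc(C(F)(F)F)cc2)ccc1OCc1ccc(C(F)(F)F)cc1)C(=O)O`: 200 nM.

Compound 2 stands at the lower of the two numbers in this assay; compound 1 sits at a higher number, and that gap lies beyond the usual scatter. Compound 3, `CCCC/C(=C\c1cc(OCCC2CCCCC2)ccc1OCc1ccc(C(F)(F)F)cc1)C(=O)O`, has not yet been measured. It differs from compound 2 in a single place: cyclohexylmethyl in place of 4-(trifluoromethyl)phenyl on a saturated chain carbon bound to an oxygen on an aromatic ring. Among the compounds with values here, no measured pair shows this exact change by itself, so the size of the step cannot be read from the data. One aryl ether with a trifluoromethyl group gives way to a saturated ring, while the rest of the molecule, including the acid and the second ether, is kept. A modest weakening is expected, near the edge of the scatter, as a 2.3-fold higher number from compound 2 to compound 3 (0.35 log units; beyond the scatter). Compound 3 is therefore estimated at 450 nM, within a range from 120 nM to 2000 nM.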

Compound 3, half-maximal inhibitory concentration: 400 nM
The estimate for compound 3 lay 1.1-fold (0.05 log units) above the measured number; the range from low to high includes it.
By their numbers in this assay, from the lowest: compounds 2 and 3 (each within the scatter of the next); then compound 1.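

In this assay, cyclohexylmethyl in place of 4-(trifluoromethyl)phenyl on a saturated chain carbon bound to an oxygen on an aromatic ring gives a 2.0-fold higher number from compound 2 to compound 3 (0.30 log units; within the scatter). Compounds 1 and 2 differ in more than one place and could not show what this single change does: at this position, neither the aromatic ring nor the trifluoromethyl group is needed for compound 3 to stay within the scatter of compound 2. No measurement here bears on why the two groups give values this close.

Still open, from the compounds shown here alone, is whether a ring is needed here at all, or whether a plain hexyl chain or an amine at this position would read the same. Also open, going by these compounds, is whether the same swap on the second ether would give a similar result.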